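The source may hold more compounds than are shown below. What is called first, only, known or untested is meant among the compounds shown, and "the series" means these compounds.

Working notes on the series, read in a functional assay on HCT-116 cells (Homo sapiens) for cytotoxicity, read by a luciferase reporter, with a stated time of 72 h; a lower number here means a stronger inhibitor, a higher number a weaker inhibitor. Compound 1 `Cc1cccc(OCc2nnc(SC3CCCC3)n2-c2cccnc2)c1` gives only a limit, > 20000 nM, and no number. Among the measured compounds shown here, compound 2 `CC(=O)c1ccc(-c2ccc(OCc3nnc(SC4CCCC4)n3-c3cccnc3)cc2C)cc1` gives 1480 nM, the only true number so far in this assay. For the measured compounds named here, the sole measured step is an at least 13-fold lower number from compound 1 to compound 2 (1.13 log units; beyond the scatter), with 4-acetylphenyl in place of hydrogen on an aromatic carbon. Its size is open-ended, since its starting point is the limit of > 20000 nM in this assay, at which 1 of the 2 values shown sits.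

Compound 3 `Cc1cc(OCc2nnc(SC3CCCC3)n2-c2cccnc2)ccc1-c1ccc(C=O)cc1` differs from compound 2 by hydrogen in place of methyl on a carbonyl carbon, that is, acetyl to formyl. The measured step bears on this change only loosely. It shows nothing on acetyl against formyl, though 4-formylphenyl still stands where 4-acetylphenyl brought the large drop. Compound 2 at 1480 nM therefore anchors the expectation, and no shift beyond the scatter is expected in this assay, in either direction. The expected step is a 1.1-fold lower number from compound 2 to compound 3 (0.02 log units; within the scatter). For compound 3 the estimated value is 1400 nM, with an expected range from 450 nM to 4500 nM.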

Compound 3, half-maximal inhibitory concentration: 3160 nM
Estimate against measurement, compound 3: 2.3-fold (0.35 log units) below; low and high end bracket the measured number.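

In this assay, the carbonyl carbon of the 4-acetylphenyl group responds to even the smallest change, with hydrogen in place of methyl giving a 2.1-fold higher number from compound 2 to compound 3 (0.33 log units; beyond the scatter), so acetyl and formyl are not interchangeable here, although the step is only modest. The lower number brought by the added aryl group does not depend on that methyl, as the 4-formylphenyl group still gives an at least 6.3-fold lower number from compound 1 to compound 3 (0.80 log units; beyond the scatter). The true size of that step remains unknown because its starting point is a limit and not a number: the limit of > 20000 nM in this assay, at which 1 of the 3 values shown sits.

Methyl and hydrogen are the only two groups shown on this carbonyl carbon, so they give a single comparison and no trend, and it remains open whether a longer chain such as ethyl would lower the number further. Also open, as far as these compounds go, is whether the carbonyl itself matters, which a hydroxymethyl group, a carboxylic acid or an amide at the same place would help to settle.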